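The source may hold more compounds than are shown below. What is called first, only, known or untested is meant among the compounds shown, and "the series" means these compounds.

In a functional assay on HepG2 cells (Homo sapiens) for antiproliferative activity, read by MTT assay, with a stated time of 24 h (on this read-out lower numbers stand for stronger inhibition and higher numbers for weaker inhibition), compound 1 `C#CCOc1ccc2c(=O)c(-c3cc(OC)c(OC)cc3OC)coc2c1` gives 4950 nM, while compound 2 `COc1cc(OC)c(-c2coc3cc(OCc4cccc(F)c4)ccc3c2=O)cc1OC` gives 1230 nM, the lower of these two numbers. Compound 3 `COc1cc(OC)c(-c2coc3cc(OCc4cccc(Br)c4)ccc3c2=O)cc1OC` differs from compound 2 at a single place: bromo in place of fluoro on an aromatic carbon, with bromo in place of fluoro on an aromatic carbon. Within the data shown here, the only measured step nearby is a 4.0-fold lower number from compound 1 to compound 2 (0.60 log units; beyond the scatter), where 3-fluorophenyl replaced ethynyl. Among the measured compounds shown here, no measured step swaps fluoro for bromo, so no shift beyond the scatter is expected in this assay. The expected outcome is a 1.1-fold lower number from compound 2 to compound 3 (0.05 log units; within the scatter). Compound 3 is estimated at 1100 nM, with an expected range from 500 nM to 2500 nM.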

Compound 3, half-maximal inhibitory concentration: 870 nM
The estimate for compound 3 lay 1.3-fold (0.10 log units) above the measured number, within the range that was stated.
By their numbers in this assay, from the lowest: compounds 3 and 2 (each within the scatter of the next); then compound 1.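

In this assay, exchanging fluoro for bromo on the aromatic ring (a 1.4-fold lower number from compound 2 to compound 3 (0.15 log units; within the scatter)) stays within the scatter, so this position shows no measurable difference between these two halogens. The replacement of ethynyl by 3-bromophenyl (a 5.7-fold lower number from compound 1 to compound 3 (0.76 log units; beyond the scatter)) lies beyond the scatter, so the gain seen with the 3-fluorophenyl group also appears with a second halogen. Nothing available explains either result.

Still open, going by these compounds, is how a benzyl group with no halogen would compare. A carboxylic acid or an amine at this same place could also behave differently.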